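The source may hold more compounds than are shown below. What is called first, only, known or untested is meant among the compounds shown, and "the series" means these compounds.

Of the compounds shown here, two built on a shared core have been measured in a functional assay on K562 cells (Homo sapiens), read by MTT assay, with a stated time of 72 h; a lower number here means a stronger inhibitor, a higher number a weaker inhibitor. Compound 1 `O=c1[nH]cnc2c1c(-c1ccoc1)cn2[C@@H]1O[C@H](CO)[C@@H](O)[C@H]1O` carries a furan-3-yl group, and in this assay compound 1 gives 12500 nM. Compound 2 `O=c1[nH]cnc2c1c(-c1cc3ccccc3o1)cn2[C@@H]1O[C@H](CO)[C@@H](O)[C@H]1O` carries 1-benzofuran-2-yl in the same place. For compound 2 this assay reports only a limit, > 20000 nM. The step between them is an at least 1.6-fold higher number from compound 1 to compound 2 (0.20 log units; that floor lies within the scatter), so compound 2 stands no stronger than compound 1 and may be weaker; how much weaker cannot be told because one of the two values sits at the limit of > 20000 nM in this assay, at which 1 of the 2 values shown sits.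

Compound 3 `O=c1[nH]cnc2c1c(-c1ccccc1)cn2[C@@H]1O[C@H](CO)[C@@H](O)[C@H]1O` is the next member: phenyl in place of 1-benzofuran-2-yl on an aromatic carbon. Within the data shown here, the only measured step that bears on this change is the one from compound 1 to compound 2, where adding the fused second ring of 1-benzofuran-2-yl gave a number no lower than furan-3-yl. Phenyl removes that fused second ring again, so one expects compound 3 to return toward the region of compound 1 rather than stay at the limit, the change from compound 2 being estimated as an at least 1.4-fold lower number from compound 2 to compound 3 (0.15 log units; that floor lies within the scatter). Compound 3 is therefore expected near 14000 nM, between 5000 nM and 45000 nM, with a fair chance that only a limit is reported again.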

Compound 3, half-maximal inhibitory concentration: > 20000 nM
Compound 3: a limit, no number (the forecaster's own chance of this, stated with the estimate: 40%); middle value at least 1.4-fold (0.15 log units) away from the limit.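

Compound 3 shows that the fused second ring of 1-benzofuran-2-yl is not required for a result at the limit: in this assay, compound 3, with a single phenyl ring at this position, also gives only a limit, > 20000 nM. Set against furan-3-yl, the change to phenyl is an at least 1.6-fold higher number from compound 1 to compound 3 (0.20 log units; that floor lies within the scatter), so nothing here suggests that phenyl is stronger than furan-3-yl, although a real loss is not established either. The step between compound 2 and compound 3 cannot be read, and the comparison of these aromatic groups goes no further: the limit of > 20000 nM in this assay, at which 2 of the 3 values shown sit.

As far as these compounds go, compound 1 gives 12500 nM, and it remains open whether an amine, a carboxylic acid or a short alkyl chain such as methyl on this aromatic carbon would give a clearly lower number in this assay. Also open, from the compounds shown here alone, is how far the true values of compound 2 and compound 3 lie from that of compound 1, and whether they differ from each other at all.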